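This account rests on a few compounds, and the source may have more. Where it says the series, first, only, none or still open, it means among the compounds named here.

Series notes. For the measured compounds named here, compound 2 `COc1ccc(-c2cn(-c3cccc(C(=O)/C=C/c4cc(OC)c(OC)c(OC)c4)c3)c(=O)[nH]2)cc1` gives 1380 nM in a functional assay on HCT-15 cells (Homo sapiens) for inhibition (a lower number here means a stronger inhibitor of growth, a higher number a weaker inhibitor of growth), and holds the lowest number of the three measured so far. Compound 1 `COc1cc(/C=C/C(=O)c2cccc(-n3cc(-c4ccccc4)[nH]c3=O)c2)ccc1O` gives 2730 nM in this assay, a gap to compound 2 that lies within the scatter. Compound 3 `COc1ccc(-c2cn(-c3cccc(C(=O)/C=C/c4ccc(O)c(OC)c4)c3)c(=O)[nH]2)cc1` gives 3150 nM, and the step of a 2.3-fold higher number from compound 2 to compound 3 (0.36 log units; beyond the scatter) is modest but beyond the scatter. The step of a 1.2-fold higher number from compound 1 to compound 3 (0.06 log units; within the scatter) is within the scatter.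

Compound 4 `COc1cc(/C=C/C(=O)c2cccc(-n3cc(-c4cc(OC)c(OC)c(OC)c4)[nH]c3=O)c2)cc(OC)c1OC` has not been measured. Relative to compound 2 the change is 3,4,5-trimethoxyphenyl in place of 4-methoxyphenyl on an aromatic carbon. Going by the values given here, only the step from compound 1 to compound 3 bears directly on it, since it also adds methoxy on an aromatic carbon of this five-membered ring substituent, and that step was within the scatter. The step from compound 2 to compound 3 changes the other arm and shows that the trimethoxy pattern there goes with the lower number, but it does not speak to this ring. The expected step of a 1.2-fold lower number from compound 2 to compound 4 (0.06 log units; within the scatter) is therefore small, likely within the scatter. Compound 4 is estimated at 1200 nM, with a range of 500 nM to 3000 nM.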

Compound 4, concentration for 50% growth inhibition: 1890 nM
Compound 4: the middle estimate sits 1.6-fold (0.20 log units) below what was measured; low and high end bracket the measured number.
By their numbers in this assay, from the lowest: compounds 2, 4, 1 and 3 (each within the scatter of the next, the first and the last beyond it).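

In this assay, for the compounds shown here, the step of a 1.4-fold higher number from compound 2 to compound 4 (0.14 log units; within the scatter) is the first reading of a change in substitution on the aryl group at this position with the other arm held fixed as 3,4,5-trimethoxyphenyl. On this aromatic carbon of the five-membered aromatic ring with 2 nitrogen, the larger 3,4,5-trimethoxyphenyl therefore sits within the scatter of 4-methoxyphenyl, and the extra methoxy groups give no separation in this read-out. No measurement at hand accounts for this result.

Still open, going by these compounds, is whether a group of another kind on this carbon, such as a morpholine, a carboxylic acid or a straight alkyl chain, would separate from these aryl groups. Also open, on these data alone, is how 3,4,5-trimethoxyphenyl at this position reads with 4-hydroxy-3-methoxyphenyl on the other arm.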